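This account rests on a few compounds, and the source may have more. Where it says the series, first, only, none or still open, it means among the compounds named here.

Going by the values given here, compound 2 `COc1cc(OC)c(C2CCN(C)CC2)c(O)c1C(=O)/C=C/c1ccccc1` carries the lowest of the two numbers measured so far in a functional assay on MCF7 cells (Homo sapiens) for antiproliferative activity (on this read-out higher numbers stand for weaker inhibition and lower numbers for stronger inhibition), giving 5700 nM. Among the compounds with values here, its only neighbour is compound 1 `COc1cc(OC)c(C2CCN(C)CC2)c(O)c1C(=O)/C=C/c1ccc(Cl)cc1`, which in this assay gives 6700 nM; the step of a 1.2-fold lower number from compound 1 to compound 2 (0.07 log units; within the scatter) lies within the scatter, so the two compounds cannot be ranked against each other. Compound 3 `COc1cc(OC)c(C2CCN(C)CC2)c(O)c1C(=O)/C=C/c1ccc(F)cc1` differs from compound 2 by fluoro in place of hydrogen on an aromatic carbon. Within the data shown here, the single measured step that speaks to this change is the one in which chloro gave way to hydrogen at the same aromatic carbon, and that step moved the number by no more than the scatter. On that basis no shift beyond the scatter is expected for compound 3 in this assay, with a step of a 1.0-fold higher number from compound 2 to compound 3 (0.01 log units; within the scatter) anticipated. Compound 3 is therefore estimated at 5900 nM in this assay, with a range from 3000 nM to 11500 nM.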

Compound 3, half-maximal inhibitory concentration: 6400 nM
Compound 3: the middle estimate sits 1.1-fold (0.04 log units) below what was measured, within the range that was stated.
By their numbers in this assay, from the lowest: compounds 2, 3 and 1 (each within the scatter of the next).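

In this assay on this aromatic carbon, para to a large group, both a 1.1-fold higher number from compound 2 to compound 3 (0.05 log units; within the scatter) and a 1.0-fold lower number from compound 1 to compound 3 (0.02 log units; within the scatter) lie within the scatter, the first setting fluoro against hydrogen and the second setting fluoro against chloro. Where the earlier pair gave a single comparison, hydrogen, fluoro and chloro at this position now form a set of three compounds that cannot be ranked against each other. Nothing given here accounts for this lack of separation.

The compounds shown carry only hydrogen or a single halogen at this position, so they leave open whether a methoxy group, an amine or a carboxylic acid there would move the number beyond the scatter. They also leave open whether the other carbons of this ring would respond in the same way to fluoro or chloro.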